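The source may hold more compounds than are shown below. What is called first, only, known or untested is meant among the compounds shown, and "the series" means these compounds.

Measured so far in an assay on U2OS cells for inhibition of secreted frizzled-related protein 1 (Homo sapiens), read by a luciferase reporter, with a stated time of 18 h; on this read-out higher numbers stand for an effect only at larger amounts of compound and lower numbers for an effect already at smaller amounts:
- compound 1 `CN(C)c1ccc(C(=O)N2CCC(NS(=O)(=O)c3cc(S(=O)(=O)c4ccccc4)ccc3C(F)(F)F)CC2)cc1`: 190 nM
- compound 2 `CC(C)(C)OC(=O)N1CCC[C@@H]1C(=O)N1CCC(NS(=O)(=O)c2cc(S(=O)(=O)c3ccccc3)ccc2C(F)(F)F)CC1`: 210 nM

Compound 2 and compound 1 sit together on these numbers; the step of a 1.1-fold higher number from compound 1 to compound 2 (0.04 log units; within the scatter) is within the scatter, so the two cannot be told apart. That step exchanged the whole group on the carbonyl carbon, and the read-out did not move beyond the scatter.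

Compound 3 `CC(C)(C)OC(=O)N1CC[C@H](C(=O)N2CCC(NS(=O)(=O)c3cc(S(=O)(=O)c4ccccc4)ccc3C(F)(F)F)CC2)C1` is next. It differs from compound 2 as follows: 1-(tert-butoxycarbonyl)pyrrolidin-3-yl in place of 1-(tert-butoxycarbonyl)pyrrolidin-2-yl on a carbonyl carbon. Within the data shown here, the change lies on the same carbonyl carbon as the one measured step, which is the only step that bears on it; no measured pair compares the pyrrolidin-2-yl with the pyrrolidin-3-yl attachment. Given that the one step at this position stayed within the scatter, no step beyond the scatter is expected here either, and the estimated step is a 1.1-fold higher number from compound 2 to compound 3 (0.04 log units; within the scatter). Compound 3 is therefore expected to give about 230 nM, with a range from 90 nM to 600 nM.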

Compound 3, half-maximal effective concentration: 150 nM
The estimate for compound 3 lay 1.5-fold (0.19 log units) above the measured number, and the stated range covers the measured number.
By their numbers in this assay, from the lowest: compounds 3, 1 and 2 (each within the scatter of the next).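

In this assay, among these compounds, moving the attachment on the carbonyl carbon from 1-(tert-butoxycarbonyl)pyrrolidin-2-yl to 1-(tert-butoxycarbonyl)pyrrolidin-3-yl gives a 1.4-fold lower number from compound 2 to compound 3 (0.15 log units; within the scatter) and is the first comparison of attachment points on this ring; the two cannot be told apart. The exchange of 4-(dimethylamino)phenyl for 1-(tert-butoxycarbonyl)pyrrolidin-3-yl gives a 1.3-fold lower number from compound 1 to compound 3 (0.10 log units; within the scatter) and so adds a second comparison at this place with no separation, leaving all three groups on this carbonyl carbon within the scatter of the next. No measurement at hand bears on this result.

Open, going by these compounds, is whether any group at this place moves the number beyond the scatter, for example a free pyrrolidine amine in place of the tert-butoxycarbonyl-protected ring, or a carboxylic acid on that ring. Also open, on these data alone, is the effect of the opposite configuration at the defined stereocentre of either pyrrolidine.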